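A few compounds are considered here, and "the series" means these few. Any claim that something is new, unique, unknown or untested is made for them only; others in the source may bear on it.

In an assay on HEK-293T cells for inhibition of diacylglycerol lipase-alpha (Homo sapiens), read by colorimetric assay (a higher number here means a weaker inhibitor, a lower number a stronger inhibitor), compound 1 `O=C(CCCCCCc1ccccc1)c1ncc(C(=O)C(F)(F)F)o1` gives 1820 nM. Compound 2 `CSc1cnc(C(=O)CCCCCCc2ccccc2)o1` gives > 10000 nM, which is a limit rather than a number. Compound 3 `COc1ccc(-c2cnc(C(=O)CCCCCCc3ccccc3)o2)cc1` likewise gives > 10000 nM, again only a limit. Among the three values shown, compound 3 therefore sits at the limit of > 10000 nM in this assay, at which 2 of the 3 values shown sit, with no number of its own. The measured steps of an at least 5.4-fold higher number from compound 1 to compound 2 (0.73 log units; beyond the scatter) and an at least 5.4-fold higher number from compound 1 to compound 3 (0.73 log units; beyond the scatter) both end at that limit, and the step that the two limits leave unreadable from compound 2 to compound 3 cannot be sized from two limits. Compound 4 `COc1ccc(-c2cnc(C(=O)CCCCCCc3ccccc3)o2)nc1` differs from compound 3 by 5-methoxypyridin-2-yl in place of 4-methoxyphenyl on an aromatic carbon. Among the compounds with values here, none of the measured steps exchanges one aryl group for another at this position, so they bear on the new change only by showing that compound 3 offers no number from which to move. The expected step that the limit leaves unreadable from compound 3 to compound 4 is therefore small, and the result is most likely again a limit. Compound 4 is thus estimated at 15000 nM, within 5000 nM to 50000 nM, in this assay.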

Compound 4, half-maximal inhibitory concentration: > 10000 nM
Compound 4: a limit, no number; the forecaster's own chance of this, stated with the estimate: 80%; the middle value is on the limit's open side.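

In this assay compound 4 gives > 10000 nM, which is a limit and not a number. Within the data shown here, the exchange of 4-methoxyphenyl for 5-methoxypyridin-2-yl, the first change between two aryl groups at this position, yields no number, so the steps that link compound 4 to compound 2 and compound 3 cannot be read, and the only readable step is an at least 5.4-fold higher number from compound 1 to compound 4 (0.73 log units; beyond the scatter). Of the groups shown on this aromatic carbon, only the (trifluoromethyl)carbonyl of compound 1 leaves a number, and a third compound now joins the others: the limit of > 10000 nM in this assay, at which 3 of the 4 values shown sit.

The compounds shown leave open how far compound 2, compound 3 and compound 4 differ from one another, as their limits hide any gap. They also leave open whether a nitrile, a carboxylic acid or an amide on this carbon would give a number in this assay.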